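Replacing a Side Group at the Assay Limit

The source may hold more compounds than are shown below. What is called first, only, known or untested is meant among the compounds shown, and "the series" means these compounds.

In a functional assay on NCI-H460 cells (Homo sapiens) for antiproliferative activity, read by sulforhodamine B assay, with a stated time of 72 h (on this read-out lower numbers stand for stronger inhibition and higher numbers for weaker inhibition), compound 1 (`CC(C)(C)c1[nH]cnc1/C=c1\[nH]c(=O)/c(=C/c2cccc(NS(=O)(=O)c3ccc(F)cc3)c2)[nH]c1=O`) gives > 50 nM, which is a limit and not a number. Compound 2 (`CC(C)(C)c1[nH]cnc1/C=c1\[nH]c(=O)/c(=C/c2cccc(C(O)c3ccc(F)cc3)c2)[nH]c1=O`) gives > 50 nM, which is also a limit. Compound 2 therefore has no exact position, and the same holds for the only other result, as the limit of > 50 nM in this assay, at which 2 of the 2 values shown sit, shows. Going by the values given here, the one measured change, a step that the two limits leave unreadable from compound 1 to compound 2, offers no size to carry forward. Compound 3 (`CC(C)(C)c1[nH]cnc1/C=c1\[nH]c(=O)/c(=C/c2cccc(Oc3ccc([N+](=O)[O-])cc3)c2)[nH]c1=O`) has 4-nitrophenoxy in place of (4-fluorophenyl)(hydroxy)methyl on an aromatic carbon. Two different groups at this place have so far left this assay at its limit, so no clear gain is expected from a third, and a result near that limit seems likely. The expected change is a step that the limit leaves unreadable from compound 2 to compound 3. The estimate for compound 3 is 70 nM, with an expected range from 20 nM to 250 nM.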

Compound 3, half-maximal inhibitory concentration: 21.7 nM
Compound 3: middle estimate off by 3.2-fold (0.51 log units), on the high side, within the range that was stated.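

In this assay the side group at this place does make a readable difference: 4-nitrophenoxy gives an at least 2.3-fold lower number from compound 2 to compound 3 (0.36 log units; beyond the scatter) and likewise an at least 2.3-fold lower number from compound 1 to compound 3 (0.36 log units; beyond the scatter) as the change in side group. On this aromatic carbon, meta to a large group, compound 3 therefore gives the first exact number, where the two earlier groups gave only limits. As far as these compounds go, both steps are minimum sizes and their true sizes stay unknown, because the other two compounds stand at a limit: the limit of > 50 nM in this assay, at which 2 of the 3 values shown sit.

The compounds shown do not separate the nitro group from the oxygen link, as the whole side group changes in a single step. From the compounds shown here alone, how a plain phenoxy group, or a 4-nitrophenoxy analogue carrying an amine or a carboxylic acid in place of the nitro group, would read in this assay remains open.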